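Extending the amino-acid ester side chain of an indolyl maleimide

The source may report more compounds than this note shows. Statements on the series, on what has been measured and on what is new or still open speak of the compounds shown alone.

Measured so far:
compound 1 `COC(=O)[C@H](NC(=O)Cn1cc(C2=C(c3c[nH]c4ccccc34)C(=O)N(C)C2=O)c2ccccc21)[C@@H](C)O` gives 22900 nM;
compound 2 `COC(=O)CCNC(=O)Cn1cc(C2=C(c3c[nH]c4ccccc34)C(=O)N(C)C2=O)c2ccccc21` gives 47800 nM;
compound 3 `COC(=O)[C@@H](CO)NC(=O)Cn1cc(C2=C(c3c[nH]c4ccccc34)C(=O)N(C)C2=O)c2ccccc21` gives 24500 nM.

All three share one core and differ only in the amino-acid-like group on the amide-type nitrogen. In a functional assay on MCF7 cells (Homo sapiens) for cytotoxicity, read by MTT assay, with a stated time of 24 h (a lower number here means a stronger inhibitor, a higher number a weaker inhibitor), compound 1 has the lowest number of the three, yet compound 3 sits within the scatter of it, so the two cannot be ranked; only compound 2 stands apart, as a 2.1-fold higher number from compound 1 to compound 2 (0.32 log units; beyond the scatter) shows.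

Compound 4 `COC(=O)CC[C@@H](NC(=O)Cn1cc(C2=C(c3c[nH]c4ccccc34)C(=O)N(C)C2=O)c2ccccc21)C(=O)OC` has not been measured. It differs from compound 1 in one place: 2-(methoxycarbonyl)ethyl in place of 1-hydroxyethyl on a saturated chain carbon bound to an amide-type nitrogen and a carbonyl carbon. The nearest measured steps are a 2.1-fold higher number from compound 1 to compound 2 (0.32 log units; beyond the scatter), where the group carrying the hydroxyl is replaced by an ester chain, and a 1.1-fold higher number from compound 1 to compound 3 (0.03 log units; within the scatter), where only a methyl is removed. The former bears most on this change, since compound 4 likewise loses the hydroxyl group while keeping the ester next to the nitrogen. A modest rise in the number, beyond the scatter, is therefore expected, a 1.5-fold higher number from compound 1 to compound 4 (0.18 log units; within the scatter). Compound 4 is estimated at 35000 nM, within 15000 nM to 80000 nM.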

Compound 4, half-maximal inhibitory concentration: 23400 nM
The estimate for compound 4 lay 1.5-fold (0.17 log units) above the measured number; measured number inside the range.
By their numbers in this assay, from the lowest: compounds 1, 4, 3 and 2 (each within the scatter of the next, the first and the last beyond it).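

In this assay, going by these compounds alone, the side chain tolerates a much larger change at this position than the earlier compounds showed: putting 2-(methoxycarbonyl)ethyl in place of 1-hydroxyethyl gives a 1.0-fold higher number from compound 1 to compound 4 (0.01 log units; within the scatter), with the hydrogen-bond donor gone and the group going from 3 to 6 heavy atoms. Replacing hydroxy with (methoxycarbonyl)methyl likewise gives a 1.0-fold lower number from compound 3 to compound 4 (0.02 log units; within the scatter), so a hydroxyl is not required on this chain for a number at this level. The loss of the hydroxyl therefore cannot alone account for compound 2, since adding the second ester-bearing branch gives a 2.0-fold lower number from compound 2 to compound 4 (0.31 log units; beyond the scatter), although compound 4 has no hydroxyl either.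

From the compounds shown here alone, whether a carboxylic acid in place of the methyl ester, or an amine on this chain, would leave the number unchanged remains open. Nothing measured here explains why these different groups give such similar numbers.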